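A few compounds are considered here, and "the series" means these few. Any claim that something is new, unique, unknown or untested is made for them only; others in the source may bear on it.

Working notes on the series. Compound 1 `Cc1cc(COc2ccc(F)c(F)c2)nc(-c2ccccn2)n1` and compound 2 `CC1(CS(C)(=O)=O)CN(c2cc(COc3ccc(F)c(F)c3F)nc(-c3ccccn3)n2)C1` share a core; in a functional assay on cells for antagonist activity at Free fatty acid receptor 1 (Homo sapiens), read by TR-FRET and inositol phosphate accumulation, with a stated time of 2 h (on this read-out lower numbers stand for stronger inhibition and higher numbers for weaker inhibition), compound 1 gives 501 nM, while compound 2 gives 6310 nM. For the measured compounds named here, compound 2 thus stands at the higher of the two numbers measured so far, and compound 1 stands well apart from it; the two compounds differ in more than one place, so no single step connects them.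

Compound 3 `CC1(COc2cc(COc3ccc(F)c(F)c3F)nc(-c3ccccn3)n2)COC1` follows from compound 2 by one change: (3-methyloxetan-3-yl)methoxy in place of 3-methyl-3-((methylsulfonyl)methyl)azetidin-1-yl on an aromatic carbon. Going by the values given here, nothing measured so far isolates the effect of exchanging a group at this position on the core, so no step beyond the scatter is expected in this assay, in either direction. The estimate for compound 3 in this assay is 5000 nM, with a range from 1500 nM to 15000 nM. This estimate means a step of a 1.3-fold lower number from compound 2 to compound 3 (0.10 log units; within the scatter) that is expected to remain within the usual scatter.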

Compound 3, half-maximal inhibitory concentration: 79.4 nM
Compound 3: middle estimate off by 63-fold (1.80 log units), on the high side; the measured number lies below the stated range.
By their numbers in this assay, from the lowest: compound 3; then compound 1; then compound 2.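

Exchanging 3-methyl-3-((methylsulfonyl)methyl)azetidin-1-yl for (3-methyloxetan-3-yl)methoxy on this aromatic carbon gives a 79-fold lower number from compound 2 to compound 3 (1.90 log units; beyond the scatter) in this assay, so the substituent at this position of the shared core has a strong bearing on the read-out. The exchange alters several features at once: the leaving group has 10 heavy atoms, including nitrogen and sulfur, while the entering group has 7 heavy atoms and neither element, although each holds a four-membered non-aromatic ring with 1 hetero atom. No measured evidence bears on why the number moves this far.

The compounds shown leave open which feature of the exchange carries the step. An amine in place of the ether oxygen, with the 3-methyloxetan-3-yl group kept, or a plain methoxy group at this position, would help separate these contributions.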